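A few compounds are considered here, and "the series" means these few. Any claim that something is new, unique, unknown or untested is made for them only; others in the source may bear on it.

In a functional assay on KBVIN cells (Homo sapiens) for antiproliferative activity, read by sulforhodamine B assay, with a stated time of 3 days (on this read-out higher numbers stand for an effect only at larger amounts of compound and lower numbers for an effect already at smaller amounts), compound 1 (`CCC1=C(O)c2c(oc(-c3ccc(CC(C)C)cc3)cc2=O)C(CC)(CC)C1=O`) gives 17.4 uM, compound 2 (`CCC1=C(O)c2c(oc(-c3ccc(O)cc3)cc2=O)C(CC)(CC)C1=O`) gives 20.6 uM and compound 3 (`CCC1=C(O)c2c(oc(-c3ccc(OC)cc3)cc2=O)C(CC)(CC)C1=O`) gives 0.68 uM. Compound 3 holds the lowest number of the three, and its gaps to both others lie beyond the scatter. The other two do not separate, with a 1.2-fold higher number from compound 1 to compound 2 (0.07 log units; within the scatter).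

Next in the series is compound 4 (`CCC1=C(O)c2c(oc(-c3ccc(F)cc3)cc2=O)C(CC)(CC)C1=O`), with fluoro in place of methoxy on an aromatic carbon, para to a large group: fluoro in place of methoxy on an aromatic carbon. Among the measured compounds shown here, no measured compound carries fluoro, so the evidence is indirect. The relevant steps change the group at this same place, and both are large: a 26-fold lower number from compound 1 to compound 3 (1.41 log units; beyond the scatter) and a 30-fold lower number from compound 2 to compound 3 (1.48 log units; beyond the scatter). Among these three compounds, only the methoxy compound has a low number, while isobutyl and hydroxy sit together high. Losing methoxy is therefore expected to raise the number in this assay by a step beyond the scatter, though possibly not all the way to the level of compound 1 and compound 2, as fluoro is untested. The expected change is an 8.8-fold higher number from compound 3 to compound 4 (0.95 log units; beyond the scatter). For compound 4 the estimated value is 6 uM, with an expected range from 1.5 uM to 22 uM.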

Compound 4, concentration for half-maximal effect: 1.85 uM
The estimate for compound 4 lay 3.2-fold (0.51 log units) above the measured number; the range from low to high includes it.
By their numbers in this assay, from the lowest: compound 3; then compound 4; then compounds 1 and 2 (each within the scatter of the next).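

Among the compounds shown here, at the place para to a large group, the change from 4-methoxyphenyl to 4-fluorophenyl in this assay gives a 2.7-fold higher number from compound 3 to compound 4 (0.43 log units; beyond the scatter) and so shows that methoxy is not the only group here that gives a low number, although compound 3 still holds the lowest. The steps of an 11-fold lower number from compound 2 to compound 4 (1.05 log units; beyond the scatter) and a 9.4-fold lower number from compound 1 to compound 4 (0.97 log units; beyond the scatter) place fluoro clear of hydroxy and isobutyl, so the series now falls into three levels rather than two: methoxy, then fluoro, then hydroxy and isobutyl together. No measurement accompanies these numbers that could account for this order.

The compounds shown leave open whether the low numbers extend to other groups at this place, such as chloro, ethoxy or a dimethylamino group, and whether any of them would reach or pass the level of methoxy. Going by these compounds, it is also open whether methoxy and fluoro keep their order with the group on another carbon of the same aromatic ring or with a different substituent on the shared core.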